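Amide cap of compound 3 swapped from hydroxymethyl to tert-butyl

The source may hold more compounds than are shown below. What is called first, only, known or untested is meant among the compounds shown, and "the series" means these compounds.

In an assay on isolated protein for displacement of a labelled ligand from 5-hydroxytryptamine receptor 6 (Homo sapiens) (on this read-out higher numbers stand for weaker inhibition and lower numbers for stronger inhibition), compound 3 `O=C(CO)NC[C@@H]1CCCc2cc(S(=O)(=O)c3cccc(F)c3)ccc21` gives 0.1 nM, the lowest of the three numbers shown. Compound 2 `CC(=O)N(C)C[C@@H]1CCCc2cc(S(=O)(=O)c3cccc(F)c3)ccc21` gives 1.59 nM and compound 1 `CN(C)C(=O)NC[C@@H]1CCCc2cc(S(=O)(=O)c3cccc(F)c3)ccc21` gives 2.51 nM. Compound 4 `CC(C)(C)C(=O)NC[C@@H]1CCCc2cc(S(=O)(=O)c3cccc(F)c3)ccc21` differs from compound 3 by tert-butyl in place of hydroxymethyl on a carbonyl carbon. Going by the values given here, two measured steps bear on this position, both ending at the hydroxymethyl carbonyl of compound 3: a 25-fold lower number from compound 1 to compound 3 (1.40 log units; beyond the scatter) and a 16-fold lower number from compound 2 to compound 3 (1.20 log units; beyond the scatter). In both the hydroxymethyl variant carries the clearly lower number, so moving from hydroxymethyl to tert-butyl is expected to raise the number in this assay by a broadly similar amount. Compound 4 is therefore estimated at 2 nM, with a range of 0.5 nM to 8 nM. The expected step is a 20-fold higher number from compound 3 to compound 4 (1.30 log units; beyond the scatter), beyond the scatter.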

Compound 4, inhibition constant: 3.98 nM
Beside the measured number, compound 4's estimate is 2.0-fold (0.30 log units) below it, and the stated range covers the measured number.
By their numbers in this assay, from the lowest: compound 3; then compounds 2, 1 and 4 (each within the scatter of the next, the first and the last beyond it).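

In this assay tert-butyl on this carbonyl carbon brings a 40-fold higher number from compound 3 to compound 4 (1.60 log units; beyond the scatter) and so gives up the low number seen with hydroxymethyl. Against the other two compounds there is a 2.5-fold higher number from compound 2 to compound 4 (0.40 log units; beyond the scatter) and also a 1.6-fold higher number from compound 1 to compound 4 (0.20 log units; within the scatter) so among the four compounds only compound 3 stands clearly apart from all the others. No measured evidence here accounts for these steps.

Still open, from the compounds shown here alone, is whether a methoxymethyl or aminomethyl cap would keep the number of compound 3. A plain methyl cap and a longer chain such as 2-hydroxyethyl also remain to be placed.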